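Substituted phenyl amides: the step from compound 3

The compounds below may be only part of what the source reports. "The series", "measured", "known", "first", "only" and "open" are said of these compounds alone.

In an ADME assay on HEp-2 cells (Homo sapiens) for cytotoxicity (a lower number here means that less compound is tolerated, a higher number that more compound is tolerated), the phenyl amide compound 1 `O=C(Nc1ccccc1)[C@@H]1CCCN1S(=O)(=O)c1cccc2cccnc12` gives 35600 nM. Compound 2 `Cc1ccc(Cl)cc1NC(=O)[C@@H]1CCCN1S(=O)(=O)c1cccc2cccnc12` gives 10000 nM, and compound 3 `Cc1ccc(C(C)C)cc1NC(=O)[C@@H]1CCCN1S(=O)(=O)c1cccc2cccnc12` gives 9700 nM. Two substituted phenyl groups have been measured, and they give a 3.6-fold lower number from compound 1 to compound 2 (0.55 log units; beyond the scatter) and a 3.7-fold lower number from compound 1 to compound 3 (0.56 log units; beyond the scatter). Isopropyl in place of chloro then gives a 1.0-fold lower number from compound 2 to compound 3 (0.01 log units; within the scatter), which is within the scatter. Compound 3 therefore stands level with compound 2, and both stand apart from compound 1.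

The next compound is compound 4 `Cc1ccc(Cl)c(NC(=O)[C@@H]2CCCN2S(=O)(=O)c2cccc3cccnc23)c1`, which brings 2-chloro-5-methylphenyl in place of 5-isopropyl-2-methylphenyl on an amide-type nitrogen. Going by the values given here, no measured compound carries this exact group, so the expectation is borrowed from its nearest relatives. The 5-chloro-2-methylphenyl of compound 2 has the same two substituents, and exchanging chloro for isopropyl there made no step beyond the scatter, as a 1.0-fold lower number from compound 2 to compound 3 (0.01 log units; within the scatter) shows. Both substituted examples also keep well clear of the value of compound 1 at 35600 nM. In this assay the expected change is small and within the scatter, an estimated 1.1-fold higher number from compound 3 to compound 4 (0.05 log units; within the scatter). For compound 4 the estimated value is 11000 nM, with an expected range of 5500 nM to 24000 nM.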

Compound 4, half-maximal cytotoxic concentration: > 50000 nM
Compound 4 ended at the assay's limit; the forecaster's own chance of this, stated with the estimate: 10%; at least 4.5-fold (0.65 log units) between middle value and limit.
By their numbers in this assay, from the lowest: compounds 3 and 2 (each within the scatter of the next); then compound 1. At a limit, above all of these: compound 4.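

Compound 4 stands at a limit in this assay, > 50000 nM, which is not a number, so every step to it is a floor: the limit of > 50000 nM in this assay, at which 1 of the 4 values shown sits. Moving from 5-chloro-2-methylphenyl to 2-chloro-5-methylphenyl keeps the same two substituents yet gives an at least 5.0-fold higher number from compound 2 to compound 4 (0.69 log units; beyond the scatter), and the change from 5-isopropyl-2-methylphenyl gives an at least 5.1-fold higher number from compound 3 to compound 4 (0.71 log units; beyond the scatter), so on this amide-type nitrogen the arrangement of chloro and methyl matters, whereas exchanging chloro for isopropyl between compound 2 and compound 3 left the number within the scatter. Against the unsubstituted phenyl the reading is an at least 1.4-fold higher number from compound 1 to compound 4 (0.14 log units; that floor lies within the scatter), a floor within the scatter, so substitution on this phenyl does not always bring the lower number seen for compound 2 and compound 3, and compound 4 goes against any such rule.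

As far as these compounds go, how far compound 4 lies past the limit stays open, as does whether the chloro or the methyl of 2-chloro-5-methylphenyl alone carries the step. Also open, from the compounds shown here alone, is what a methoxy or a carboxylic acid in place of that chloro would give in this assay.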